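A few compounds are considered here, and "the series" means these few. Any claim that something is new, unique, unknown or untested is made for them only; others in the source may bear on it.

In a functional assay on DLD-1 cells (Homo sapiens) for cytotoxicity, with a stated time of 48 h (on this read-out higher numbers stand for weaker inhibition and lower numbers for stronger inhibition), three compounds sharing one core have been measured. Compound 1 (`CCCCOc1ccc2oc(/C=C/[S+](C)[O-])cc(=O)c2c1`) gives 4800 nM, and compound 2 (`CC(C)CCOc1ccc2oc(/C=C/[S+](C)[O-])cc(=O)c2c1`) gives 4100 nM. Compound 3 (`CC(C)C(=O)Oc1ccc2oc(/C=C/[S+](C)[O-])cc(=O)c2c1`), with isopropylcarbonyl on the oxygen on the aromatic ring, gives 9100 nM. Its place among them is set by two steps: a 1.9-fold higher number from compound 1 to compound 3 (0.28 log units; within the scatter), and a 2.2-fold higher number from compound 2 to compound 3 (0.35 log units; beyond the scatter).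

Compound 4 (`C[S+]([O-])/C=C/c1cc(=O)c2cc(OC(=O)C(C)(C)C)ccc2o1`) differs from compound 3 by one change, (methyl in place of hydrogen on a saturated chain carbon bound to a carbonyl carbon and two saturated chain carbons), which turns isopropylcarbonyl to (tert-butyl)carbonyl. The closest measured precedent is a 1.2-fold lower number from compound 1 to compound 2 (0.07 log units; within the scatter), also methyl in place of hydrogen, but on a saturated chain carbon bound to two saturated chain carbons. Among the measured compounds shown here, no measured step places methyl on a carbon bound to a carbonyl carbon, so this precedent is only indirect. With that single small step as a guide, no step beyond the scatter is expected in this assay, and no firm direction can be given. The estimated step is a 1.1-fold lower number from compound 3 to compound 4 (0.03 log units; within the scatter). The expected value for compound 4 is 8500 nM, with an estimated range from 4200 nM to 17000 nM.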

Compound 4, half-maximal inhibitory concentration: 8000 nM
Compound 4: the middle estimate sits 1.1-fold (0.03 log units) above what was measured, and the stated range covers the measured number.
By their numbers in this assay, from the lowest: compounds 2, 1, 4 and 3 (each within the scatter of the next, the first and the last beyond it).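

In this assay, the step from isopropylcarbonyl to (tert-butyl)carbonyl is a 1.1-fold lower number from compound 3 to compound 4 (0.06 log units; within the scatter), so methyl on a saturated chain carbon bound to a carbonyl carbon and two saturated chain carbons has now been read directly. The same change on the butyl-type chain and on this carbonyl-bearing group gives matching results: the same change on two cores in this assay, a 1.2-fold lower number (0.07 log units; within the scatter) from compound 1 to compound 2 and a 1.1-fold lower number (0.06 log units; within the scatter) from compound 3 to compound 4, 1.0-fold (0.01 log units) apart, within the scatter of two such steps. The (tert-butyl)carbonyl group also stays within the scatter of both chains on the oxygen, with a 1.7-fold higher number from compound 1 to compound 4 (0.22 log units; within the scatter) and a 2.0-fold higher number from compound 2 to compound 4 (0.29 log units; within the scatter), although isopropylcarbonyl was separated from isopentyl by a 2.2-fold higher number from compound 2 to compound 3 (0.35 log units; beyond the scatter).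

The compounds shown leave open how a longer chain, or a chain ending in an amine or a carboxylic acid, would read on this oxygen. They also leave open whether methyl in place of hydrogen would behave the same way on any other carbon of these groups.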